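This account rests on a few compounds, and the source may have more. Where it says the series, first, only, none or still open, it means among the compounds named here.

Measured so far in an assay on CHO-K1 cells for displacement of a labelled ligand from adenosine receptor A1 (Homo sapiens), read by scintillation counting, with a stated time of 60 min, tested at 1 uM; a higher number here means more inhibition at the concentration tested (going by the name of the read-out), a lower number less inhibition:

compound 1 `CC(=O)Nc1ccc(/C=N/Nc2nc(N)c3ncn([C@@H]4O[C@H](CO)[C@@H](O)[C@H]4O)c3n2)cc1`, giving 0%
compound 2 `CCCOc1ccc(/C=N/Nc2nc(N)c3ncn([C@@H]4O[C@H](CO)[C@@H](O)[C@H]4O)c3n2)cc1`, giving 7%
compound 3 `Nc1nc(N/N=C/c2ccc(Cl)c(C(F)(F)F)c2)nc2c1ncn2[C@@H]1O[C@H](CO)[C@@H](O)[C@H]1O`, giving 11%

All three compounds share one core and differ only in the aromatic group hanging from the carbon with a double bond to nitrogen. Going by the values given here, compound 3 gives the highest of the three numbers, but the margins are small: the step of a number 4 percentage points higher from compound 2 to compound 3 (within the scatter) stays within the scatter, and only the step of a number 11 percentage points higher from compound 1 to compound 3 (beyond the scatter) reaches beyond it, and then only modestly. In short, none of the three shows much inhibition at the concentration tested.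

Compound 4 `CN(C)c1ccc(/C=N/Nc2nc(N)c3ncn([C@@H]4O[C@H](CO)[C@@H](O)[C@H]4O)c3n2)cc1` has not yet been measured. Compared with compound 3 the change is 4-(dimethylamino)phenyl in place of 4-chloro-3-(trifluoromethyl)phenyl on a carbon with a double bond to nitrogen.

Among the compounds with values here, no measured step swaps in a 4-(dimethylamino)phenyl group, so nothing bears on it directly. Within the data shown here, the two steps that do touch this position, a number 11 percentage points higher from compound 1 to compound 3 (beyond the scatter) and a number 4 percentage points higher from compound 2 to compound 3 (within the scatter), show that exchanging one aromatic group for another at this place has moved the read-out only slightly, and every value so far sits near the bottom of the scale. The expectation for compound 4 is therefore a step of a number 7 percentage points lower from compound 3 to compound 4 (within the scatter), a small decrease or none beyond the scatter. Compound 4 is estimated to give 4%, with a range from 0% to 13%.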

Compound 4, a percentage reported as inhibition, at one concentration (the size of the read-out at that concentration, not a potency): 0%
Compound 4: middle estimate off by 4 percentage points, on the high side; measured number inside the range.
By their numbers in this assay, from the lowest: compounds 1, 4, 2 and 3 (each within the scatter of the next, the first and the last beyond it).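

In this assay, the change to a 4-(dimethylamino)phenyl group gives a number 11 percentage points lower from compound 3 to compound 4 (beyond the scatter) and so shows that a second group, alongside the 4-acetamidophenyl group of compound 1, lies beyond the scatter from the 4-chloro-3-(trifluoromethyl)phenyl group. On the aromatic carbon, dimethylamino in place of acetamido gives no change at the digits printed from compound 1 to compound 4 (within the scatter) while dimethylamino in place of propoxy gives a number 7 percentage points lower from compound 2 to compound 4 (within the scatter) and thus adds a third group to those that this read-out cannot separate at this low end of the scale, with compound 2 going against any clean split because it also lies within the scatter of compound 3. Nothing available here accounts for why these groups read as they do.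

Going by these compounds, whether a primary amine or a carboxylic acid on the aromatic ring, or an alkoxy chain longer than propoxy, would lift the number well clear of these low values remains open. On these data alone, an unsubstituted phenyl group at the same carbon is also missing from these compounds, so the effect of carrying no added group on the ring is unknown.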